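Urea nitrogen substitution in the fluorobenzyl triazole series

A few compounds are considered here, and "the series" means these few. Any claim that something is new, unique, unknown or untested is made for them only; others in the source may bear on it.

Compound 3 `NC(=O)N1CCN(C(=S)SCc2cn(Cc3ccc(F)cc3)nn2)CC1` gives 9330 nM in a functional assay on MGC-803 cells (Homo sapiens) for cytotoxicity, read by MTT assay, with a stated time of 72 h; on this read-out higher numbers stand for weaker inhibition and lower numbers for stronger inhibition. Among the three measured compounds it stands second highest on the numbers, with compound 1 `NC(=O)N1CCN(C(=S)SCc2cn(Cc3ccccc3F)nn2)CC1` nearest, which in this assay gives 11300 nM, and compound 2 `CCN(C)C(=O)N1CCN(C(=S)SCc2cn(Cc3ccccc3F)nn2)CC1` furthest, which gives 5860 nM. All three values lie within the scatter of one another, so no ranking among them can be read from them, and the step of a 1.2-fold lower number from compound 1 to compound 3 (0.08 log units; within the scatter) carries no direction of its own.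

Compound 4 `O=C(NC1CCCCC1)N1CCN(C(=S)SCc2cn(Cc3ccc(F)cc3)nn2)CC1` differs from compound 3 by cyclohexyl in place of hydrogen on an amide-type nitrogen. Going by the values given here, the only measured step at the same place is a 1.9-fold lower number from compound 1 to compound 2 (0.29 log units; within the scatter), a substitution on the same amide-type nitrogen, and it stayed within the scatter. Among the compounds with values here, no measured step involves a cyclohexyl group, so the size of this particular change is not covered by the series so far. The expected step is therefore a 1.7-fold lower number from compound 3 to compound 4 (0.23 log units; within the scatter), small and, if anything, towards a lower number, with no step beyond the scatter anticipated. Compound 4 is estimated at 5500 nM in this assay, with a range from 2200 nM to 14000 nM.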

Compound 4, half-maximal inhibitory concentration: > 128000 nM
Compound 4: only a limit was reported; the forecaster's own chance of this, stated with the estimate: 3%; middle value at least 23-fold (1.36 log units) away from the limit.
By their numbers in this assay, from the lowest: compounds 2, 3 and 1 (each within the scatter of the next). At a limit, above all of these: compound 4.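

In this assay, going by these compounds alone, the amide-type nitrogen proves sensitive to what it carries: cyclohexyl in place of hydrogen gives an at least 13-fold higher number from compound 3 to compound 4 (1.13 log units; beyond the scatter), the only step so far that lies beyond the scatter. The earlier change on the same nitrogen, ethyl(methyl)amino in place of amino, gave a 1.9-fold lower number from compound 1 to compound 2 (0.29 log units; within the scatter), so compound 2 goes against any reading that carbon substitution on this nitrogen by itself brings a loss of inhibition. Compound 4 stands at a limit of the assay and not at a number: the limit of > 128000 nM in this assay, at which 1 of the 4 values shown sits.

As far as these compounds go, the full size of the step therefore stays open, and the two steps at this nitrogen also differ in whether the amide hydrogen remains and start from different fluorophenyl compounds. With cyclohexyl as the only ring here, the compounds shown do not tell whether a cyclopropyl group, a phenyl group or a longer chain ending in an amine on this nitrogen would stay close to compound 3 or follow compound 4.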